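This account rests on a few compounds, and the source may have more. Where it says the series, first, only, none or still open, it means among the compounds named here.

Compound 1 `CCC1(Cc2ccccc2)OS(=O)(=O)C=C1OCC(=O)OC` reaches only a limit of > 200000 nM in an ADME assay on HEL cells (Homo sapiens) for cytotoxicity, with a stated time of 3 days; a higher number here means that more compound is tolerated, a lower number that less compound is tolerated. Compound 2 `CCC1(Cc2ccccc2)OS(=O)(=O)C=C1OCc1ccc(Br)cc1` gives 171000 nM in this assay.

Going by the values given here, the result for compound 1 is a limit (the limit of > 200000 nM in this assay, at which 1 of the 2 values shown sits), so compound 2 provides the only plain number of the pair, and nothing in these two values separates the compounds. The step to the untested compound 3 `CCC1(Cc2ccccc2)OS(=O)(=O)C=C1OC(=O)c1ccccc1` is benzoyl in place of 4-bromobenzyl on an oxygen on an unsaturated carbon. Among the compounds with values here, the one measured step that bears on this change, an at least 1.1-fold lower number from compound 1 to compound 2 (0.06 log units; that floor lies within the scatter), also altered the group carried by the oxygen on the unsaturated carbon, although there it was a swap on a saturated chain carbon bound to that oxygen rather than a swap of the group attached to the oxygen itself; that step stayed within the scatter. Within the data shown here, with only that comparison available, and with both shared-core compounds tolerated up to very high concentrations, no step beyond the scatter is expected in this assay in either direction. Compound 3 is therefore estimated at about 160000 nM, within a range of 60000 nM to 400000 nM. The expected step is a 1.1-fold lower number from compound 2 to compound 3 (0.03 log units; within the scatter).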

Compound 3, half-maximal cytotoxic concentration: > 200000 nM
Compound 3 ended at the assay's limit; the forecaster's own chance of this, stated with the estimate: 40%; at least 1.2-fold (0.09 log units) between middle value and limit.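

On the oxygen on an unsaturated carbon, benzoyl in place of 4-bromobenzyl puts a carbonyl directly on that oxygen and gives, in this assay, an at least 1.1-fold higher number from compound 2 to compound 3 (0.06 log units; that floor lies within the scatter), so the part of this change that can be read stays within the scatter. Compound 3 gives > 200000 nM, which is a limit and not a number. What is new for this position is that a group joined to the oxygen through a carbonyl also reaches the limit, as the (methoxycarbonyl)methyl group of compound 1 did, and the step between those two compounds cannot be read, with the limit now shared: the limit of > 200000 nM in this assay, at which 2 of the 3 values shown sit.

As far as these compounds go, how far compound 1 and compound 3 would differ if each had a plain number remains open, as does the true size of the step to compound 3. Also open, from the compounds shown here alone, is whether an amine, a carboxylic acid or a longer chain on this same oxygen would leave the read-out as high as these groups do on the shared core.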